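The compounds below may be only part of what the source reports. "The series", "measured", "known", "first", "only" and "open" are said of these compounds alone.

Measured compounds:
compound 1, `Cn1c(COc2cccc(C(=O)O)c2)nc2ccc(Oc3ccc(F)cc3)nc21`: 8.6 10^-6 cm/s
compound 2, `Cc1ccc(Oc2ccc3nc(COc4cccc(C(=O)O)c4)n(C)c3n2)c(C)c1`: 28.8 10^-6 cm/s

In an ADME assay for permeability, using PAMPA, with a stated time of 4 h (a higher number here means that the compound crosses the layer faster, a lower number that the compound crosses the layer more slowly), compound 1 stands lowest of the two numbers; its nearest neighbour is compound 2, and the step is a 3.3-fold higher number from compound 1 to compound 2 (0.52 log units; beyond the scatter), which changes nothing else but the group on the oxygen on the aromatic ring.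

Compound 3, `Cn1c(COc2cccc(C(=O)O)c2)nc2ccc(Oc3ccc4c(c3)CCC4)nc21`, has not yet been measured. It differs from compound 1 in one place: 2,3-dihydro-1H-inden-5-yl in place of 4-fluorophenyl on an oxygen on an aromatic ring. For the measured compounds named here, the only measured step that bears on this change is the one from compound 1 to compound 2, where a different carbon-only aromatic group took the same place on the same oxygen and the number rose by a 3.3-fold higher number from compound 1 to compound 2 (0.52 log units; beyond the scatter). The step to compound 3 is therefore expected to lie in the same direction and of a similar size, as a 2.9-fold higher number from compound 1 to compound 3 (0.46 log units; beyond the scatter). For compound 3 in this assay the estimated number is 25 10^-6 cm/s, with a range from 12 10^-6 cm/s to 50 10^-6 cm/s.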

Compound 3, apparent permeability: 31.5 10^-6 cm/s
Estimate against measurement, compound 3: 1.3-fold (0.10 log units) below; low and high end bracket the measured number.
By their numbers in this assay, from the lowest: compound 1; then compounds 2 and 3 (each within the scatter of the next).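

In this assay, the step with 2,3-dihydro-1H-inden-5-yl in place of 4-fluorophenyl on the oxygen is a 3.7-fold higher number from compound 1 to compound 3 (0.56 log units; beyond the scatter), so a second group without fluorine also goes with a higher number at this place, and neither listed replacement goes against this. The two replacements are not separated, with a 1.1-fold higher number from compound 2 to compound 3 (0.04 log units; within the scatter), so at this place the five-membered non-aromatic ring of carbon only and the two methyl groups give the same number within the scatter. Nothing in the data available explains these steps.

The compounds shown leave open whether plain phenyl would already give the higher number, or whether a phenyl carrying an amine or a methoxy group would do the same. They also leave open whether these steps hold when an amide takes the place of the carboxylic acid.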